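Hydroxy to trifluoromethoxy: a step from a limit

The source may hold more compounds than are shown below. What is called first, only, known or untested is meant among the compounds shown, and "the series" means these compounds.

Compound 1 (`Cc1cc(NC(=O)Nc2ccc(F)cc2)c2ccccc2n1`): > 25000 nM (a limit)
Compound 2 (`Cc1cc(NC(=O)Nc2ccc(O)cc2)c2ccccc2n1`): > 25000 nM (a limit)

Both compounds were tested in an ADME assay on Raji cells (Homo sapiens) for cytotoxicity, with a stated time of 72 h (on this read-out higher numbers stand for an effect only at larger amounts of compound and lower numbers for an effect already at smaller amounts), and neither gave an exact number. Going by these compounds, compound 2 stands at > 25000 nM and that is a limit of the assay, so its true value is unknown. The next compound is compound 3 (`Cc1cc(NC(=O)Nc2ccc(OC(F)(F)F)cc2)c2ccccc2n1`), where hydroxy becomes trifluoromethoxy. The change is trifluoromethyl in place of hydrogen on an oxygen on an aromatic ring and it places trifluoromethyl in place of hydrogen on an oxygen on an aromatic ring.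

Among the measured compounds shown here, only one measured step bears on this change, and it swaps a different group on the same ring. That step is a step that the two limits leave unreadable from compound 1 to compound 2 and it gives no size to carry forward. All that can be said is the limit of > 25000 nM in this assay, at which 2 of the 2 values shown sit, and no more. For the measured compounds named here, with only that unreadable step from compound 1 as a guide, no shift beyond the scatter in this assay is expected, in either direction. The estimated change is a number no higher from compound 2 to compound 3 (the limit leaves the size open) with no direction foreseen. Compound 3 is expected at 25000 nM with an estimated range of 12000 nM to 50000 nM and the assay may well report only a limit again.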

Compound 3, half-maximal effective concentration: 10000 nM
The estimate for compound 3 lay 2.5-fold (0.40 log units) above the measured number; the measured number lies below the stated range.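

In this assay, putting trifluoromethyl in place of hydrogen on the oxygen on the aromatic ring gives an at least 2.5-fold lower number from compound 2 to compound 3 (0.39 log units; beyond the scatter), which shows that a change at this place on the shared core can move the read-out beyond the usual scatter. Trifluoromethoxy in place of fluoro at the same place gives an at least 2.5-fold lower number from compound 1 to compound 3 (0.39 log units; beyond the scatter), so the same result appears whether compound 3 is compared with the hydroxy compound or the fluoro compound. The earlier step from fluoro to hydroxy cannot be read, and compound 3 is the only one of the three with an exact number: the limit of > 25000 nM in this assay, at which 2 of the 3 values shown sit.

Going by these compounds, both new steps start from a limit, so their true sizes remain open, and the three compounds do not show whether the drop needs the oxygen, the fluorines or both. Also open, on these data alone, is how this assay would respond to methoxy, which carries methyl on the same oxygen, to trifluoromethyl set directly on the aromatic carbon, or to an amine or a carboxylic acid at this place.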